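Selenium substituent series on the shared core: compound 4

The source may report more compounds than this note shows. Statements on the series, on what has been measured and on what is new or still open speak of the compounds shown alone.

Compound 3 `Nc1nc([SeH])nc2ccccc12` reaches in a functional assay on MCF7 cells (Homo sapiens) for cytotoxicity, read by MTT assay, with a stated time of 72 h (a lower number here means that less compound is tolerated, a higher number that more compound is tolerated), only a limit of the assay, > 100000 nM. Compound 1 `C[Se]c1nc(N)c2ccccc2n1` likewise sits at a limit in this assay, > 100000 nM. Compound 2 `CCCCC[Se]c1nc([Se]CCCCC)c2ccccc2n1` also gives a limit in this assay, > 100000 nM. Within the data shown here, the single measured step between compounds that differ in one place, a step that the two limits leave unreadable from compound 1 to compound 3, is therefore not readable in size, and the only evidence on the measured steps is the limit of > 100000 nM in this assay, at which 3 of the 3 values shown sit.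

Compound 4 `CCCCC[Se]c1nc(N)c2ccccc2n1` differs from compound 3 by pentyl in place of hydrogen on a selenium. Among the measured compounds shown here, the one step on this selenium, a step that the two limits leave unreadable from compound 1 to compound 3, runs between two limits and gives no size; compound 2, with pentyl on both selenium atoms, also stands at its limit. No readable step bears on the change, so no step beyond the scatter is expected in this assay in either direction. Compound 4 is expected to give 150000 nM in this assay, within 50000 nM to 500000 nM. This expectation corresponds to the estimated step that the limit leaves unreadable from compound 3 to compound 4.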

Compound 4, concentration lethal to 50% of the cells: 90400 nM
Beside the measured number, compound 4's estimate is 1.7-fold (0.22 log units) above it; measured number inside the range.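

Among these compounds, compound 4 is the first of the series to give a number rather than a limit in this assay, so the selenium substituent can now be tied to a readable value at one end. Pentyl in place of hydrogen on a selenium gives an at least 1.1-fold lower number from compound 3 to compound 4 (0.04 log units; that floor lies within the scatter), butyl in place of hydrogen on a saturated chain carbon bound to a selenium atom gives an at least 1.1-fold lower number from compound 1 to compound 4 (0.04 log units; that floor lies within the scatter), and one nitrogen atom in place of a group of 6 heavy atoms gives an at least 1.1-fold lower number from compound 2 to compound 4 (0.04 log units; that floor lies within the scatter). All three are floors, not sizes, and the series still rests largely on one limit: the limit of > 100000 nM in this assay, at which 3 of the 4 values shown sit.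

Going by these compounds, the true size of each step stays open. Also open, on these data alone, is whether a chain longer than pentyl on the selenium, or a carboxylic acid at the end of the chain, would shift the number further.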